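The source may report more compounds than this note shows. Statements on the series, on what has been measured and on what is new or still open speak of the compounds shown alone.

Series notes. The shared core is carried by compound 1 `Cc1ccc(Nc2cc(C)nc(SCc3nc4ccccc4[nH]3)n2)cc1`, compound 2 `Cc1cc(Nc2ccc(F)cc2)nc(SCc2nc3ccccc3[nH]2)n1`, compound 3 `Cc1cc(NC(C)C)nc(SCc2nc3ccccc3[nH]2)n1` and the not yet measured compound 4 `Cc1cc(N(C)Cc2ccccc2)nc(SCc2nc3ccccc3[nH]2)n1`. In a functional assay on MCF7 cells (Homo sapiens) for cytotoxicity, read by MTT assay, with a stated time of 72 h (a lower number here means a stronger inhibitor, a higher number a weaker inhibitor), compound 1 gives 56500 nM. In this assay compound 2 gives 42200 nM. For compound 3 only a limit of the assay is recorded, > 100000 nM, and that is the limit (the limit of > 100000 nM in this assay, at which 1 of the 3 values shown sits). Compound 3 thus stands at the upper edge of the numbers shown, reached by the steps of an at least 1.7-fold higher number from compound 1 to compound 3 (0.24 log units; that floor lies within the scatter) and an at least 2.3-fold higher number from compound 2 to compound 3 (0.37 log units; beyond the scatter).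

The step to compound 4 is benzyl(methyl)amino in place of isopropylamino on an aromatic carbon. For the measured compounds named here, no measured step exchanges one substituent on that ring nitrogen for another of this shape; the nearest evidence is that compound 1 and compound 2, each carrying an aromatic ring on that nitrogen, return numbers, whereas compound 3 returns only a limit. The expectation for this assay is therefore a modest lowering of the number, with a real chance of a second limit. Compound 4 is expected to give 70000 nM, estimated between 25000 nM and 200000 nM. The expected step is an at least 1.4-fold lower number from compound 3 to compound 4 (0.15 log units; that floor lies within the scatter).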

Compound 4, half-maximal inhibitory concentration: > 100000 nM
Compound 4: only a limit was reported; the forecaster's own chance of this, stated with the estimate: 40%; middle value at least 1.4-fold (0.15 log units) away from the limit.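

In this assay compound 4 gives only a limit of the assay, > 100000 nM, the second such entry for a group at this position: the limit of > 100000 nM in this assay, at which 2 of the 4 values shown sit. Benzyl(methyl)amino carries an aromatic ring, yet no number returns, so an aromatic ring somewhere in this group is not enough to give a value within the range of the assay. Replacing (4-fluorophenyl)amino gives an at least 2.3-fold higher number from compound 2 to compound 4 (0.37 log units; beyond the scatter), replacing (4-methylphenyl)amino gives an at least 1.7-fold higher number from compound 1 to compound 4 (0.24 log units; that floor lies within the scatter), and the step between the two limit entries cannot be read.

The compounds shown leave open whether a benzylamino group, which keeps the hydrogen on the nitrogen, would return a number, or whether only an aromatic ring set directly on that nitrogen does. A morpholine at this position, or a carboxylic acid on the 4-fluorophenyl ring, also remains unplaced.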